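This account rests on a few compounds, and the source may have more. Where it says the series, first, only, none or still open, it means among the compounds named here.

Compound 1 `CC(=O)Nc1ccc(S(=O)(=O)NNC(=O)c2cccnc2Nc2ccc(Cl)cc2)cc1` was examined in a functional assay on CCRF-CEM cells (Homo sapiens) for antiproliferative activity; on this read-out lower numbers stand for higher toxicity in this test and higher numbers for lower toxicity in this test. In this assay compound 1 gives > 100000 nM, which is a limit of the assay and not a number. Among the compounds with values here, compound 2 `O=C(NNS(=O)(=O)c1ccc(F)cc1)c1cccnc1Nc1ccc(Cl)cc1Cl` is the only other measured member of the set. In this assay compound 2 gives > 100000 nM, again a limit rather than a measured number. Compound 1 therefore stands at the edge of what the assay reports: the limit of > 100000 nM in this assay, at which 2 of the 2 values shown sit. Compound 3 `O=C(NNS(=O)(=O)c1ccc(Cl)cc1Cl)c1cccnc1Nc1ccc(Cl)cc1` has not yet been measured. It differs from compound 1 by 2,4-dichlorophenyl in place of 4-acetamidophenyl on a sulfonyl sulfur. Within the data shown here, no step between two measured compounds is available to set a size for such a change. Compound 3 is expected to show a step of a number no higher from compound 1 to compound 3 (the limit leaves the size open), nothing beyond the scatter, because of the limit of > 100000 nM in this assay, at which 2 of the 2 values shown sit. For compound 3 the estimate in this assay is 100000 nM, within a range from 30000 nM to 100000 nM, most probably returned once more only as a limit.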

Compound 3, concentration lethal to 50% of the cells: > 100000 nM
Compound 3: only a limit was reported; the forecaster's own chance of this, stated with the estimate: 80%; the middle value sits exactly at the limit.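

Within the data shown here, compound 1 and compound 3 are both reported in this assay only as limits, so no step between them can be read. The compounds shown leave open how far past that limit each one lies, and whether exchanging 4-acetamidophenyl for 2,4-dichlorophenyl changes this read-out at all.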